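Dropping the Trifluoromethyl Group from the Side Chain of Compound 3

The source may report more compounds than this note shows. Statements on the series, on what has been measured and on what is new or still open speak of the compounds shown alone.

Compound 1 `CN1[C@@H]2c3[nH]c4ccccc4c3C[C@H]1[C@H](C#N)N1[C@@H](CNC(=O)c3cccc(C(F)(F)F)c3)c3[nH]c4ccccc4c3C[C@@H]21` gives 340 nM in a functional assay on HepG2 cells (Homo sapiens) for cytotoxicity, read by MTT assay, with a stated time of 72 h; on this read-out lower numbers stand for stronger inhibition and higher numbers for weaker inhibition.
Compound 2 `CN1[C@@H]2c3[nH]c4ccccc4c3C[C@H]1[C@H](C#N)N1[C@@H](CNC(=O)c3ccc(F)cc3)c3[nH]c4ccccc4c3C[C@@H]21` gives 210 nM in this assay.
Compound 3 `CN1[C@@H]2c3[nH]c4ccccc4c3C[C@H]1[C@H](C#N)N1[C@@H](CNC(=O)/C=C/c3cccc(C(F)(F)F)c3)c3[nH]c4ccccc4c3C[C@@H]21` gives 540 nM in this assay.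

All three compounds share one core and differ only in the group attached to the carbonyl carbon of the amide. Compound 3 carries the highest number of the three: one step is a 1.6-fold higher number from compound 1 to compound 3 (0.20 log units; within the scatter), while the other is a 2.6-fold higher number from compound 2 to compound 3 (0.41 log units; beyond the scatter). The change a 1.6-fold lower number from compound 1 to compound 2 (0.21 log units; within the scatter) swaps one substituted aryl group for another.

Compound 4 `CN1[C@@H]2c3[nH]c4ccccc4c3C[C@H]1[C@H](C#N)N1[C@@H](CNC(=O)/C=C/c3ccccc3)c3[nH]c4ccccc4c3C[C@@H]21` keeps the ethenyl-linked arrangement of compound 3 and differs by hydrogen in place of trifluoromethyl on an aromatic carbon. Among the measured compounds shown here, no measured pair removes a trifluoromethyl group outright; the closest guide is compound 1 to compound 2, where exchanging one ring substituent for another moved the number only within the scatter. Compound 4 is therefore expected to land close to compound 3, with an estimated step of a 1.1-fold lower number from compound 3 to compound 4 (0.03 log units; within the scatter) in this assay, and no direction beyond the scatter can be predicted with confidence. The estimated value for compound 4 is 500 nM, with a range of 220 nM to 1100 nM.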

Compound 4, half-maximal inhibitory concentration: 470 nM
Compound 4: the middle estimate sits 1.1-fold (0.03 log units) above what was measured, and the stated range covers the measured number.
By their numbers in this assay, from the lowest: compounds 2, 1, 4 and 3 (each within the scatter of the next, the first and the last beyond it).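

In this assay, among the compounds shown here, this is the first direct reading of what the trifluoromethyl group contributes on an aromatic carbon of the side chain, meta to a large group: its replacement by hydrogen leaves the two compounds within the scatter (a 1.1-fold lower number from compound 3 to compound 4 (0.06 log units; within the scatter)). The step to compound 4 from the aryl amide with a 4-fluorophenyl group lies beyond the scatter (a 2.2-fold higher number from compound 2 to compound 4 (0.35 log units; beyond the scatter)), while the step from the aryl amide with a 3-(trifluoromethyl)phenyl group stays within it (a 1.4-fold higher number from compound 1 to compound 4 (0.14 log units; within the scatter)), so the gap between compound 2 and the ethenyl-linked compounds remains without the trifluoromethyl group. Nothing available here explains why the trifluoromethyl group can be exchanged for hydrogen with so little visible effect on the number.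

The gap to compound 2 could come from the ethenyl link, from the ring's fluorine, or from both, since that step changes the two together. As far as these compounds go, it also remains open whether this ring carbon would accept a larger or very different group, such as an amine, a carboxylic acid or a longer carbon chain, as readily as it accepts hydrogen.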